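Azoxy chain series: carbamoyl to hydroxyethyl exchange

This account rests on a few compounds, and the source may have more. Where it says the series, first, only, none or still open, it means among the compounds named here.

compound 1 `COC[C@H](/N=[N+](\[O-])CCCCCCC(C)=O)[C@H](C)O` — > 50 ug/mL
compound 2 `CCCCCCCC/[N+]([O-])=N/[C@@H](COC)C(N)=O` — 38.2 ug/mL

In a functional assay on HUVEC cells (Homo sapiens) for antiproliferative activity (a higher number here means a weaker inhibitor of growth, a lower number a stronger inhibitor of growth), compound 1 gives only a limit, > 50 ug/mL. Within the data shown here, compound 2 gives 38.2 ug/mL in this assay, the only numerical value in the set. The other value, that of compound 1, is a limit (the limit of > 50 ug/mL in this assay, at which 1 of the 2 values shown sits).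

Compound 3 `CCCCCCCC/[N+]([O-])=N/[C@@H](COC)[C@H](C)O` differs from compound 2 by 1-hydroxyethyl in place of carbamoyl on a saturated chain carbon bound to a double-bonded nitrogen and a saturated chain carbon. Among the measured compounds shown here, no measured step covers this change. A small shift is expected, toward weaker growth inhibition if anything, with a fair chance the read-out again reaches the limit. Compound 3 is estimated at 45 ug/mL, range 20 ug/mL to 100 ug/mL, meaning an expected step of a 1.2-fold higher number from compound 2 to compound 3 (0.07 log units; within the scatter).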

Compound 3, concentration for 50% growth inhibition: > 50 ug/mL
Compound 3 gave a limit, no number; the forecaster's own chance of this, stated with the estimate: 45%; middle value at least 1.1-fold (0.04 log units) away from the limit.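

In this assay, going by these compounds, 1-hydroxyethyl in place of carbamoyl on this saturated chain carbon gives an at least 1.3-fold higher number from compound 2 to compound 3 (0.11 log units; that floor lies within the scatter); since this is only a floor, the true size of the change remains unknown. Compound 3 and compound 1 both give limits, so the step between them cannot be read. Compound 2 is left as the only compound with a numerical read-out, while the others sit at one limit: the limit of > 50 ug/mL in this assay, at which 2 of the 3 values shown sit.

On these data alone, whether an amine or a carboxylic acid on this carbon would give a numerical read-out remains open. The same question stands for a longer chain.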